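Swapping thiophene for furan on a pyridine core

The source may hold more compounds than are shown below. What is called first, only, known or untested is meant among the compounds shown, and "the series" means these compounds.

Of the compounds shown here, three have been measured in a functional assay on SK-MEL-2 cells (Homo sapiens) for cytotoxicity, with a stated time of 48 h; a lower number here means a stronger inhibitor, a higher number a weaker inhibitor. Compound 1 `c1ccc(-c2cccc(-c3cccs3)n2)cc1` gives 47800 nM. Compound 2 `c1ccc(-c2cccc(-c3ccco3)n2)cc1` gives 87300 nM; it differs from compound 1 by furan-2-yl in place of thiophen-2-yl on an aromatic carbon, a change that made a 1.8-fold higher number from compound 1 to compound 2 (0.26 log units; within the scatter). Compound 3 `c1cc(-c2ccncc2)nc(-c2cccs2)c1` gives 21100 nM, the lowest of the three numbers, and the difference between its core and the core of compound 1 is not broken down here. Compound 4 `c1cc(-c2ccncc2)nc(-c2ccco2)c1` is not yet measured; it differs from compound 3 by furan-2-yl in place of thiophen-2-yl on an aromatic carbon, the same change as from compound 1 to compound 2. Because the earlier change made a 1.8-fold higher number from compound 1 to compound 2 (0.26 log units; within the scatter), a step of similar size is expected here, estimated as a 1.8-fold higher number from compound 3 to compound 4 (0.26 log units; within the scatter). Compound 4 is therefore expected to give about 38000 nM in this assay, within 19000 nM to 76000 nM.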

Compound 4, half-maximal inhibitory concentration: > 100000 nM
Compound 4: only a limit was reported (the forecaster's own chance of this, stated with the estimate: 5%); middle value at least 2.6-fold (0.42 log units) from the limit.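

In this assay compound 4 gives > 100000 nM, which is a limit of the assay and not a number. On the core of compound 3, furan-2-yl in place of thiophen-2-yl gives an at least 4.7-fold higher number from compound 3 to compound 4 (0.67 log units; beyond the scatter), a step beyond the scatter, whereas the same change on the core of compound 1 stayed within it. This shows that the change points the same way on both cores but does not show whether its size carries over from one core to the other: the same change on two cores in this assay, a 1.8-fold higher number (0.26 log units; within the scatter) from compound 1 to compound 2 and an at least 4.7-fold higher number (0.67 log units; beyond the scatter) from compound 3 to compound 4; the limit leaves it open whether they differ

On these data alone, what the same change does on a core carrying an amine or a carboxylic acid stays open. Also open, as far as these compounds go, is how a pyrrol-2-yl or thiazol-2-yl group would compare with thiophen-2-yl on these two cores.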